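This account rests on a few compounds, and the source may have more. Where it says the series, first, only, none or still open, it means among the compounds named here.

Compound 1 (`C=C[C@@](C)(/C=C/c1ccc(O)c(CO)c1)CCC=C(C)C`): 16400 nM
Compound 2 (`C=C[C@@](C)(/C=C/c1ccc(O)c(/C=C/C(=O)c2ccccc2)c1)CCC=C(C)C`): 4470 nM

Going by the values given here, in a functional assay on NALM-6 cells (Homo sapiens) for cytotoxicity, with a stated time of 72 h (on this read-out higher numbers stand for an effect only at larger amounts of compound and lower numbers for an effect already at smaller amounts), compound 2 gives 4470 nM as the lower of the two numbers measured so far, while compound 1 gives 16400 nM as its nearest neighbour, a gap beyond the usual scatter. Compound 3 (`C=C[C@@](C)(/C=C/c1ccc(O)c(/C=C/C(=O)OCC)c1)CCC=C(C)C`) has not yet been measured. It differs from compound 2 in one place: ethoxy in place of phenyl on a carbonyl carbon with ethoxy in place of phenyl on a carbonyl carbon, so that benzoyl becomes ethoxycarbonyl. Among the compounds with values here, no measured step between compounds differing in one place is available, so the data give no direct guide to this exchange in this assay and the expectation remains uncertain. A small move towards a higher number is expected, with a 1.5-fold higher number from compound 2 to compound 3 (0.16 log units; within the scatter) estimated to stay within the usual scatter. Compound 3 is estimated at 6500 nM (expected range 2500 nM to 16000 nM).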

Compound 3, half-maximal effective concentration: 20900 nM
Beside the measured number, compound 3's estimate is 3.2-fold (0.51 log units) below it, outside the stated range (above it).
By their numbers in this assay, from the lowest: compound 2; then compounds 1 and 3 (each within the scatter of the next).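

In this assay, going by these compounds alone, the exchange of phenyl for ethoxy on a carbonyl carbon gives the first reading at this place, and the step of a 4.7-fold higher number from compound 2 to compound 3 (0.67 log units; beyond the scatter) shows that benzoyl and ethoxycarbonyl are not interchangeable here. The step of a 1.3-fold higher number from compound 1 to compound 3 (0.11 log units; within the scatter) lies within the scatter, so the 2-(ethoxycarbonyl)ethenyl of compound 3 cannot be told apart from the hydroxymethyl of compound 1 on that aromatic carbon. No measurement at hand explains the step from benzoyl to ethoxycarbonyl.

The compounds shown leave open whether the lower number of compound 2 depends on the phenyl itself or on any carbon group at that carbonyl carbon. A methyl ketone, a cyclohexyl ketone or a carboxylic acid at this place would bear on that question.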